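Compound 2 and its 2,4-difluorophenoxy counterpart, compound 4

The source may hold more compounds than are shown below. What is called first, only, known or untested is meant among the compounds shown, and "the series" means these compounds.

In a functional assay on MV4-11 cells (Homo sapiens) for antiproliferative activity, read by CCK-8 assay, with a stated time of 72 h (a lower number here means a stronger inhibitor, a higher number a weaker inhibitor), compound 2 (`Cc1cc(F)cc(C)c1Oc1ccc(C(C)(C)O)cc1-c1cn(C)c(=O)c2[nH]c(C(=O)NCCCCCCC(=O)NO)cc12`) gives 300 nM. That value lies within the scatter of compound 3 (`Cc1ccccc1-c1cn(C)c(=O)c2[nH]c(C(=O)NCc3ccc(C(=O)Nc4ccccc4N)cc3)cc12`) at 310 nM and of compound 1 (`Cc1cc(F)cc(C)c1Oc1ccc(C(C)(C)O)cc1-c1cn(C)c(=O)c2[nH]c(C(=O)NCc3ccc(C(=O)NO)cc3)cc12`) at 440 nM. Compound 4 (`Cn1cc(-c2cc(C(C)(C)O)ccc2Oc2ccc(F)cc2F)c2cc(C(=O)NCCCCCCC(=O)NO)[nH]c2c1=O`) differs from compound 2 in one place: 2,4-difluorophenyl in place of 4-fluoro-2,6-dimethylphenyl on an oxygen on an aromatic ring. Among the compounds with values here, the only measured single-place step, a 1.5-fold lower number from compound 1 to compound 2 (0.17 log units; within the scatter), concerns the chain on the amide nitrogen and leaves the group on the oxygen untouched. Within the data shown here, no measured step tests this exchange, so the data offer no sign of a shift, and no step beyond the scatter is expected in this assay. The estimated step is a 1.1-fold lower number from compound 2 to compound 4 (0.03 log units; within the scatter). Compound 4 is expected at 280 nM, with an estimated range of 110 nM to 700 nM.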

Compound 4, half-maximal inhibitory concentration: 250 nM
Compound 4: the middle estimate sits 1.1-fold (0.05 log units) above what was measured; measured number inside the range.
By their numbers in this assay, from the lowest: compounds 4, 2, 3 and 1 (each within the scatter of the next).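

In this assay, within the data shown here, the exchange of 4-fluoro-2,6-dimethylphenyl for 2,4-difluorophenyl on the oxygen gives a 1.2-fold lower number from compound 2 to compound 4 (0.08 log units; within the scatter) and is the first measured change at this position. The two groups cannot be told apart by this read-out, at least with the 5-(hydroxycarbamoyl)pentyl chain in place. Nothing available explains this result. As far as these compounds go, it remains open whether an unsubstituted phenyl or a pyridine ring on the oxygen would stay within the same scatter. Also open, from the compounds shown here alone, is whether 2,4-difluorophenyl behaves alike with the 4-(hydroxycarbamoyl)phenyl group of compound 1.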